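Extending the Amide Tail of Compound 2

The source may hold more compounds than are shown below. What is called first, only, known or untested is meant among the compounds shown, and "the series" means these compounds.

Three compounds sharing one core were tested in a functional assay on MCF7 cells (Homo sapiens) for antiproliferative activity, read by MTT assay, with a stated time of 72 h; on this read-out higher numbers stand for weaker inhibition and lower numbers for stronger inhibition. Compound 1 `COc1cc2ncnc(N3CCc4ccccc43)c2cc1NC(=O)C=C(C)C` gives 6390 nM, compound 2 `CC(C)=CC(=O)Nc1cc2c(N3CCc4ccccc43)ncnc2cc1O[C@@H]1CCOC1` gives 15700 nM, and compound 3 `CC(C)=CC(=O)Nc1cc2c(N3CCCc4ccccc43)ncnc2cc1O[C@@H]1CCOC1` gives 11100 nM. Compound 2 has the highest of the three numbers: the step of a 2.5-fold higher number from compound 1 to compound 2 (0.39 log units; beyond the scatter) lies beyond the scatter, whereas a 1.4-fold lower number from compound 2 to compound 3 (0.15 log units; within the scatter) stays within it. Compound 4 `O=C(/C=C/CN1CCC(CO)CC1)Nc1cc2c(N3CCc4ccccc43)ncnc2cc1O[C@@H]1CCOC1` is compound 2 with a single change: 3-(4-(hydroxymethyl)piperidin-1-yl)prop-1-en-1-yl in place of 2-methylprop-1-en-1-yl on a carbonyl carbon. For the measured compounds named here, neither measured step touches this carbonyl carbon, so no measured step bears on it directly, and the change is larger than either measured one. A step beyond the scatter is therefore plausible, but its direction is not anchored by these data. Compound 4 is expected to give 6000 nM, within 1500 nM to 25000 nM, an estimated step of a 2.6-fold lower number from compound 2 to compound 4 (0.42 log units; beyond the scatter).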

Compound 4, half-maximal inhibitory concentration: 4690 nM
The estimate for compound 4 lay 1.3-fold (0.11 log units) above the measured number; the measured number falls inside the stated range.
By their numbers in this assay, from the lowest: compounds 4, 1, 3 and 2 (each within the scatter of the next, the first and the last beyond it).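

At the carbonyl carbon of the amide tail, a far larger group than 2-methylprop-1-en-1-yl is accepted: in this assay the change gives a 3.3-fold lower number from compound 2 to compound 4 (0.52 log units; beyond the scatter). Adding a six-membered ring, a nitrogen and a hydroxyl here therefore lowers the number rather than raising it. No measurement shown accounts for this step.

As far as these compounds go, the ring, its hydroxymethyl and the longer chain all enter together, so their separate shares remain open. A plain piperidin-1-yl or a dimethylamino group at the end of the same chain would help separate them.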